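This account rests on a few compounds, and the source may have more. Where it says the series, first, only, none or still open, it means among the compounds named here.

Of the compounds shown here, three have so far been measured in a functional assay on HeLa cells (Homo sapiens) for antiproliferative activity, read by sulforhodamine B assay, with a stated time of 72 h; on this read-out lower numbers stand for stronger inhibition and higher numbers for weaker inhibition. Compound 1 `CN(C)C(=S)N/N=C/c1cc2cccnc2s1` gives 48400 nM, compound 3 `NC(=S)N/N=C/c1cc2ccccc2s1` gives 6770 nM, and compound 2 `S=C(N/N=C/c1ccc2ccccc2n1)Nc1cccc(Br)c1` gives 70000 nM. Compound 2 thus carries the highest number of the three; compound 1 sits within the scatter of it, while compound 3 lies clearly below it, beyond the scatter. Compound 4 `S=C(N/N=C/c1ccc2ccccc2n1)Nc1ccccc1` differs from compound 2 in one place: hydrogen in place of bromo on an aromatic carbon. The bromo leaves an aromatic carbon of a six-membered aromatic ring of carbon only, meta to a large group, and a hydrogen atom takes its place. Going by the values given here, no measured pair shows this change, so the expected step of no change at the digits printed from compound 2 to compound 4 (within the scatter) is small and within the scatter, with no clear direction. Compound 4 is therefore estimated at 70000 nM in this assay, with a range from 30000 nM to 160000 nM.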

Compound 4, half-maximal inhibitory concentration: 27400 nM
Estimate against measurement, compound 4: 2.6-fold (0.41 log units) above, outside the stated range (below it).
By their numbers in this assay, from the lowest: compound 3; then compounds 4, 1 and 2 (each within the scatter of the next, the first and the last beyond it).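

Taking the bromo off this aromatic carbon, the change from 3-bromophenyl to phenyl, lowers the number in this assay (a 2.6-fold lower number from compound 2 to compound 4 (0.41 log units; beyond the scatter)). Going by these compounds alone, this is the first one-place comparison in the set, and it shows that this position, meta to a large group, is not indifferent to what it carries: the compound without bromo inhibits more strongly, though only modestly. Nothing at hand explains the step. On these data alone, whether a chloro, a methoxy or an amine on this carbon would move the number further stays open, as does whether the same change would act alike on another core.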